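Swapping One Chloro for Trifluoromethyl in Compound 4

This account rests on a few compounds, and the source may have more. Where it says the series, first, only, none or still open, it means among the compounds named here.

Compound 2 `O=C(Nc1cccc(-n2cc(-c3ccncc3)c(-c3ccc(Cl)c(O)c3)n2)c1)Nc1ccc(Cl)c(Cl)c1` is compared with compound 1 `COc1cc(-c2nn(-c3cccc(NC(=O)Nc4ccc(Cl)c(Cl)c4)c3)cc2-c2ccncc2)ccc1Cl` and compound 3 `O=C(Nc1cccc(-n2cc(-c3ccncc3)c(-c3ccc(Cl)c(O)c3)n2)c1)Nc1cc(C(F)(F)F)cc(C(F)(F)F)c1` in a functional assay on UACC-257 cells (Homo sapiens) for inhibition, read by sulforhodamine B assay, with a stated time of 48 h; a higher number here means a weaker inhibitor of growth, a lower number a stronger inhibitor of growth. In this assay compound 1 gives 1040 nM, compound 2 gives 930 nM, and compound 3 gives 965 nM. Compound 2 carries the lowest of the three numbers, yet both neighbours sit within the scatter of it, so no order among the three can be claimed. Among the compounds with values here, the only single-site step that was measured, a 1.1-fold lower number from compound 1 to compound 2 (0.05 log units; within the scatter), concerns a change at a different site of the shared core from the one now altered, and it left the number within the scatter.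

Compound 4 `O=C(Nc1cccc(-n2cc(-c3ccncc3)c(-c3ccc(Cl)c(O)c3)n2)c1)Nc1ccc(Cl)c(C(F)(F)F)c1` differs from compound 2 by trifluoromethyl in place of chloro on an aromatic carbon. Within the data shown here, compounds 2 and 3 differ by more than one change and no step is given for them, but their two values are indistinguishable within the scatter, and compound 4 carries a pattern of chloro and trifluoromethyl groups lying between those two. Among the measured compounds shown here, no measured step bears directly on this swap, and the one step available was small. One therefore expects a 1.0-fold higher number from compound 2 to compound 4 (0.01 log units; within the scatter) to remain within the scatter. For compound 4 the estimate is 950 nM, with a range from 500 nM to 1800 nM.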

Compound 4, concentration for 50% growth inhibition: 768 nM
Compound 4: the middle estimate sits 1.2-fold (0.09 log units) above what was measured; measured number inside the range.
By their numbers in this assay, from the lowest: compounds 4, 2, 3 and 1 (each within the scatter of the next).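

In this assay the swap of 3,4-dichlorophenyl to 4-chloro-3-(trifluoromethyl)phenyl gives a 1.2-fold lower number from compound 2 to compound 4 (0.08 log units; within the scatter) and so leaves the two numbers indistinguishable. This is the first single-site step shown at this position, ortho to a chloro group, since the only earlier step concerned a different site of the shared core. It shows that chloro, with 1 heavy atom, and trifluoromethyl, with 4 heavy atoms, cannot be told apart here in this pair, and no information is available to explain that outcome.

The compounds shown leave open whether an amine, a carboxylic acid or a nitrile at this same position would give a number beyond the scatter of those for compound 2 and compound 4. Within the data shown here, they also leave open whether trifluoromethyl in place of chloro would give a similar step on the methyl-bearing oxygen form of the shared core found in compound 1, since this swap is seen only on the form carrying the hydrogen on that oxygen.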